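From 2,4-dimethylphenyl to 4-hydroxyphenyl in compound 2

This account rests on a few compounds, and the source may have more. Where it says the series, first, only, none or still open, it means among the compounds named here.

Compound 1 (`CC(C)=CCOc1cc(O)c2c(c1)OC(c1ccc(F)cc1)CC2=O`) gives 6060 nM in a functional assay; on this read-out higher numbers stand for weaker inhibition and lower numbers for stronger inhibition
Compound 2 (`CC(C)=CCOc1cc(O)c2c(c1)OC(c1ccc(C)cc1C)CC2=O`) gives 6380 nM in this assay

For the measured compounds named here, compound 2 stands level with compound 1, the only other measured compound, since their two values lie within the scatter of each other. Compound 3 (`CC(C)=CCOc1cc(O)c2c(c1)OC(c1ccc(O)cc1)CC2=O`) has 4-hydroxyphenyl in place of 2,4-dimethylphenyl on a saturated ring carbon, next to the ring oxygen. Going by the values given here, one measured step bears on this change, as it falls on the same carbon (a 1.1-fold higher number from compound 1 to compound 2 (0.02 log units; within the scatter)), and it replaced 4-fluorophenyl with 2,4-dimethylphenyl. Neither of those two groups carries a hydroxyl, so the data offer no direct measure of what 4-hydroxyphenyl does here. On the evidence of that single small step, no shift beyond the scatter is expected in this assay in either direction. The estimated step is small (a 1.2-fold lower number from compound 2 to compound 3 (0.06 log units; within the scatter)), although it rests on very little. For compound 3 the expected value is 5500 nM in this assay with an estimated range of 2000 nM to 15000 nM overall.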

Compound 3, half-maximal inhibitory concentration: 5340 nM
The estimate for compound 3 lay 1.0-fold (0.01 log units) above the measured number; the measured number falls inside the stated range.
By their numbers in this assay, from the lowest: compounds 3, 1 and 2 (each within the scatter of the next).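

In this assay, 4-hydroxyphenyl in place of 2,4-dimethylphenyl on this saturated ring carbon gives a 1.2-fold lower number from compound 2 to compound 3 (0.08 log units; within the scatter), so this position takes up a group with a hydrogen-bond donor and a hydrogen-bond acceptor, where the group that leaves has neither, without a step beyond the scatter. The narrower comparison, hydroxy in place of fluoro on an aromatic carbon, gives a 1.1-fold lower number from compound 1 to compound 3 (0.05 log units; within the scatter), which is also within the scatter. For the compounds shown here, the earlier step had compared only two groups without a hydroxyl, whereas these two steps show that the three substituted phenyl groups seen at this carbon all stand level in this read-out, including the one that carries a hydroxyl.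

The compounds shown leave open whether a carboxylic acid or an amine in place of the hydroxy on that aromatic carbon, or a group other than a substituted phenyl on the saturated ring carbon, would produce a step beyond the scatter. Nothing on hand speaks to what lies behind this level picture.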